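Ring Size at the Ether Oxygen: Cyclobutyl to Cyclohexyl

A few compounds are considered here, and "the series" means these few. Any claim that something is new, unique, unknown or untested is made for them only; others in the source may bear on it.

Measured compounds:
compound 1 `CC(C)Oc1cc(-c2cncc(-c3c[nH]nc3C3CC3)c2)ccc1C(N)=O`: 130 nM
compound 2 `NC(=O)c1ccc(-c2cccnc2)cc1OC1CCC1`: 1900 nM

In an assay on cells for inhibition of MAP kinase-interacting serine/threonine-protein kinase 1 (Homo sapiens), read by mobility shift assay, with stated times of 10 min and 60 min, in the presence of a further agent that is not named here (a higher number here means a weaker inhibitor, a lower number a stronger inhibitor), compound 1 gives 130 nM. In this assay compound 2 gives 1900 nM, the higher of the two numbers recorded, and its gap to compound 1 lies beyond the usual scatter. The two compounds differ in several places at once, so their pair tells nothing about any single change.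

Compound 3 `NC(=O)c1ccc(-c2cccnc2)cc1OC1CCCCC1` has not yet been measured in this assay. It differs from compound 2 by cyclohexyl in place of cyclobutyl on an oxygen on an aromatic ring. No measured pair shows this change, so there is no shown step to lean on. The expected step in this assay is small, with no clear direction, and may well fall within the scatter. Compound 3 is therefore expected to give about 1500 nM, within a range of 500 nM to 4500 nM, which would mean an estimated step of a 1.3-fold lower number from compound 2 to compound 3 (0.10 log units; within the scatter).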

Compound 3, half-maximal inhibitory concentration: 1500 nM
Compound 3: the middle estimate sits on the measured number at the digits printed; measured number inside the range.
By their numbers in this assay, from the lowest: compound 1; then compounds 3 and 2 (each within the scatter of the next).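

In this assay, among these compounds, cyclohexyl in place of cyclobutyl on an oxygen on an aromatic ring gives a 1.3-fold lower number from compound 2 to compound 3 (0.10 log units; within the scatter), the first comparison here that isolates a single change, as compound 1 and compound 2 differ in several places at once. At this position, therefore, the assay does not separate cyclobutyloxy from cyclohexyloxy, and neither ring size can be ranked above the other on these data. Nothing available here offers an explanation for this result.

Going by these compounds, it remains open whether a ring carrying an amine, such as piperidinyl, or a longer open chain at this oxygen would move the number beyond the scatter. Also unresolved is which of the several differences between compound 1 and compound 2 accounts for the gap between them.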